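Hydrogen for hydroxy: notes toward compound 4

The compounds below may be only part of what the source reports. "The series", "measured", "known", "first", "only" and "open" are said of these compounds alone.

Measured in an ADME assay on MCF7 cells (Homo sapiens) for cytotoxicity (on this read-out higher numbers stand for weaker inhibition and lower numbers for stronger inhibition), so far:
- compound 1 `Oc1cc2cc(c1)Oc1c(O)cc(cc1O)[C@H](O)CCCCCC/C=C/CCCCC2` gives 30000 nM
- compound 2 `Oc1cc2cc(c1)Oc1c(O)cc(cc1O)CCCCCCC/C=C/CCCCC2` gives 31800 nM
- compound 3 `Oc1cc2cc(c1)Oc1c(O)cc(cc1O)[C@H](O)CCCCCCCCCCCCC2` gives 30600 nM

Compound 3 (30600 nM) stands within the scatter of both compound 1 and compound 2. Compound 4 `Oc1cc2cc(c1)Oc1c(O)cc(cc1O)CCCCCCCCCCCCCC2` carries hydrogen in place of hydroxy on a saturated ring carbon of compound 3 (hydrogen in place of hydroxy on a saturated ring carbon). Going by the values given here, the only measured step of this kind is a 1.1-fold higher number from compound 1 to compound 2 (0.03 log units; within the scatter) and it lies within the scatter. On that single step, no change beyond the scatter is expected in this assay here. The estimated 1.0-fold higher number from compound 3 to compound 4 (0.02 log units; within the scatter) is therefore expected to stay within the scatter. Compound 4 is expected at 32000 nM (estimated range 20000 nM to 50000 nM).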

Compound 4, half-maximal inhibitory concentration: 32400 nM
The estimate for compound 4 lay 1.0-fold (0.01 log units) below the measured number; low and high end bracket the measured number.
By their numbers in this assay, from the lowest: compounds 1, 3, 2 and 4 (each within the scatter of the next).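

In this assay, hydrogen in place of hydroxy on a saturated ring carbon gives a 1.1-fold higher number from compound 3 to compound 4 (0.02 log units; within the scatter), so the earlier reading no longer rests on a single core. At this position, the hydroxy group has now been exchanged on two cores without a step beyond the scatter. The two steps also agree with each other: the same change on two cores in this assay, a 1.1-fold higher number (0.03 log units; within the scatter) from compound 1 to compound 2 and a 1.1-fold higher number (0.02 log units; within the scatter) from compound 3 to compound 4, 1.0-fold (0.00 log units) apart, within the scatter of two such steps.

Going by these compounds, whether an amine or a carboxylic acid on this ring carbon would give a step beyond the scatter remains open. The compounds shown also leave open how the opposite configuration at the hydroxy-bearing carbon would read.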